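A Trifluoromethyl Swap at the Assay Limit

A few compounds are considered here, and "the series" means these few. Any claim that something is new, unique, unknown or untested is made for them only; others in the source may bear on it.

Of the compounds shown here, three sharing one core have been tested in an ADME assay on HS27 cells (Homo sapiens) for antiproliferative activity, read by sulforhodamine B assay, with a stated time of 48 h; on this read-out lower numbers stand for stronger inhibition and higher numbers for weaker inhibition. Compound 1 `O=C(O)c1cc2ccc(-c3ccc(Cl)cc3)cc2n1O` gives > 100000 nM, which is a limit of the assay and not a number. Compound 2 `O=C(O)c1cc2ccc(-c3ccc(Cl)cc3Cl)cc2n1O` gives > 100000 nM, also a limit. Compound 3 `O=C(O)c1cc2ccc(-c3ccc(F)cc3)cc2n1O` gives > 100000 nM, again a limit. Going by the values given here, the whole series so far therefore stands at the limit of > 100000 nM in this assay, at which 3 of the 3 values shown sit.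

Compound 4 `O=C(O)c1cc2ccc(-c3ccc(C(F)(F)F)cc3)cc2n1O` carries trifluoromethyl in place of fluoro on an aromatic carbon, para to a large group: trifluoromethyl in place of fluoro on an aromatic carbon. Among the compounds with values here, two measured steps bear on this change. One is a step that the two limits leave unreadable from compound 1 to compound 3, which also exchanges one group for another on an aromatic carbon. The other is a step that the two limits leave unreadable from compound 1 to compound 2. Neither has a readable size, so neither offers a shift to carry over, and no change beyond the scatter is expected in this assay. The expected result is a number no higher from compound 3 to compound 4 (the limit leaves the size open). Compound 4 is estimated at 100000 nM, with an expected range from 50000 nM to 200000 nM, and will probably be reported as a limit again.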

Compound 4, half-maximal inhibitory concentration: 68000 nM
For compound 4 the middle estimate is 1.5-fold (0.17 log units) above the measured one, and the stated range covers the measured number.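

In this assay, trifluoromethyl on an aromatic carbon, para to a large group, is the only group shown that gives a readable number, whereas the steps among compound 1, compound 2 and compound 3 cannot be read. The new comparisons give an at least 1.4-fold lower number from compound 3 to compound 4 (0.16 log units; that floor lies within the scatter), and an at least 1.4-fold lower number from compound 1 to compound 4 (0.16 log units; that floor lies within the scatter); both are only floors, so neither establishes a real change at this position. Most of the series still sits at the ceiling of the assay: the limit of > 100000 nM in this assay, at which 3 of the 4 values shown sit.

The compounds shown leave open how large these two steps truly are, as the true values behind the limits remain unknown. They also leave open what an amine, a nitrile or a methoxy group would give at this same place on the shared core.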